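This account rests on a few compounds, and the source may have more. Where it says the series, first, only, none or still open, it means among the compounds named here.

Working notes on the series. Compound 1 `N#Cc1ccc(Nc2nc(Oc3ccnc4ccccc34)nc(N3CCCCC3)n2)cc1C(F)(F)F`, compound 2 `N#Cc1ccc(Nc2nc(Oc3ccnc4ccccc34)nc(N3CCN(c4ccccn4)CC3)n2)cc1C(F)(F)F` and compound 3 `N#Cc1ccc(Nc2nc(Oc3ccnc4ccccc34)nc(N3CCN(C(c4ccccc4)c4ccc(Cl)cc4)CC3)n2)cc1C(F)(F)F` share one core and differ only in the group carried on the ring nitrogen; compound 4 `N#Cc1ccc(Nc2nc(Oc3ccnc4ccccc34)nc(N3CCN(c4cccc(Cl)c4Cl)CC3)n2)cc1C(F)(F)F` is the unmeasured member. In a functional assay on DU-145 cells (Homo sapiens) for cytotoxicity, read by sulforhodamine B assay, with a stated time of 48 h (a lower number here means a stronger inhibitor of growth, a higher number a weaker inhibitor of growth), compound 1 reaches only a limit of the assay, > 100000 nM. In this assay compound 2 likewise sits at a limit, > 100000 nM. Compound 3 also gives a limit in this assay, > 100000 nM. Compound 2 therefore stands where every measured member stands, at the limit of > 100000 nM in this assay, at which 3 of the 3 values shown sit, and no number for it is known. Among the compounds with values here, the single step between measured neighbours, a step that the two limits leave unreadable from compound 1 to compound 2, cannot be read because both ends are limits. Compound 4 differs from compound 2 by 2,3-dichlorophenyl in place of pyridin-2-yl on an amine nitrogen in a ring. Within the data shown here, no measured step bears on this change with a readable size, so neither direction nor magnitude can be drawn from the data; the expectation rests only on compounds 1, 2 and 3 all sitting at the limit of > 100000 nM in this assay, at which 3 of the 3 values shown sit. Compound 4 is expected to behave the same, with an estimated value of 150000 nM and a range from 40000 nM to 600000 nM. The implied step that the limit leaves unreadable from compound 2 to compound 4 is expected to stay within the scatter, most likely returning another limit.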

Compound 4, concentration for total growth inhibition: > 100000 nM
Compound 4 gave a limit, no number (the forecaster's own chance of this, stated with the estimate: 80%); the middle value does not contradict the limit.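

No new step can be read between compound 2 and compound 4, as neither gives a number in this assay: the limit of > 100000 nM in this assay, at which 4 of the 4 values shown sit.

The compounds shown leave open whether any group on the ring nitrogen of the shared core gives a readable value in this assay, and so how these groups rank against one another.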